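Removing the aryl fluoro from the dimethylpiperazine amide

The compounds below may be only part of what the source reports. "The series", "measured", "known", "first", "only" and "open" are said of these compounds alone.

Measured in an ADME assay on microsomes from liver (Homo sapiens) for metabolic stability, read by LC-MS, using NADPH, with a stated time of 60 min, tested at 0.1 uM; a lower number here means that less of the compound is left, a higher number that more of the compound is left:
compound 1 `O=C(c1ccnc(Nc2nc3cnc(Nc4ccc(F)c(C(F)(F)F)c4)cc3[nH]2)c1)N1CCN(C2CC2)CC1`: 77%
compound 2 `C[C@@H]1CN(C(=O)c2ccnc(Nc3nc4cnc(Nc5ccc(F)c(C(F)(F)F)c5)cc4[nH]3)c2)C[C@H](C)N1`: 89%

Compound 2 stands highest of the two measured compounds at 89%, and compound 1 lies lower at 77%. The next compound is compound 3 `C[C@@H]1CN(C(=O)c2ccnc(Nc3nc4cnc(Nc5cccc(C(F)(F)F)c5)cc4[nH]3)c2)C[C@H](C)N1`, which keeps the 3,5-dimethylpiperazin-1-yl amide of compound 2 and changes the aromatic ring instead: 4-fluoro-3-(trifluoromethyl)phenyl becomes 3-(trifluoromethyl)phenyl (hydrogen in place of fluoro on an aromatic carbon). Hydrogen takes the place of fluoro on an aromatic carbon, ortho to a trifluoromethyl group and para to a large group.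

Going by the values given here, only one measured step is available, a number 12 percentage points higher from compound 1 to compound 2 (beyond the scatter). That step lies at the group on the carbonyl carbon, so it bears on this change only as a guide to how far one local edit has moved the series. Among the compounds with values here, no measured step covers the loss of the fluoro. A small downward move is therefore expected, with little room above compound 2 at 89%. The expected change is a number 5 percentage points lower from compound 2 to compound 3 (within the scatter). For compound 3 the estimated value in this assay is 84%, with an expected range of 70% to 95%.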

Compound 3, percent of the compound remaining: 86%
The estimate for compound 3 lay 2 percentage points below the measured number; low and high end bracket the measured number.
By their numbers in this assay, from the lowest: compounds 1, 3 and 2 (each within the scatter of the next, the first and the last beyond it).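

In this assay, the change of hydrogen in place of fluoro on an aromatic carbon, ortho to a trifluoromethyl group and para to a large group, gives a number 3 percentage points lower from compound 2 to compound 3 (within the scatter). Going by these compounds alone, the earlier step concerned only the group on the carbonyl carbon, whereas this one is the first reading on the aromatic ring, and with the 3,5-dimethylpiperazin-1-yl amide held constant, the fluoro can leave without a change beyond the scatter, compound 3 standing at 86%. No accompanying measurement bears on what lies behind this result.

On these data alone, the loss of the fluoro is read against the 3,5-dimethylpiperazin-1-yl amide only, so its outcome alongside the 4-cyclopropylpiperazin-1-yl amide of compound 1 remains open. Also open, as far as these compounds go, is how this aromatic carbon responds to a substituent other than fluoro or hydrogen, such as chloro, methoxy or nitrile, and whether the number holds when the trifluoromethyl group itself gives way to a group such as methyl.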